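Two methoxy additions and an expected cytotoxicity value

The source may hold more compounds than are shown below. What is called first, only, known or untested is meant among the compounds shown, and "the series" means these compounds.

Measured compounds:
compound 1, `COc1cc2c(Oc3ccc(NC(=O)c4cc(-c5ccccc5)ccn4)cc3F)ccnc2cc1OCCCN1CCN(C)CC1`: 82 nM
compound 2, `COc1ccc(-c2ccnc(C(=O)Nc3ccc(Oc4ccnc5cc(OCCCN6CCN(C)CC6)c(OC)cc45)c(F)c3)c2)cc1`: 390 nM
compound 3, `COc1ccc(-c2ccnc(C(=O)Nc3ccc(Oc4ccnc5cc(OCCCN6CCCC6)c(OC)cc45)c(F)c3)c2)cc1`: 350 nM

These numbers come from a functional assay on HT-29 cells (Homo sapiens) for cytotoxicity, read by MTT assay, with a stated time of 72 h; a higher number here means a weaker inhibitor, a lower number a stronger inhibitor. The step of a 4.8-fold higher number from compound 1 to compound 2 (0.68 log units; beyond the scatter) follows the change (methoxy in place of hydrogen on an aromatic carbon). Between the next pair the step is a 1.1-fold lower number from compound 2 to compound 3 (0.05 log units; within the scatter). The difference between the cores of compound 1 and compound 3 is not broken down here.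

Compound 4, `COc1ccc(-c2ccnc(C(=O)Nc3ccc(Oc4ccnc5cc(OCCCN6CCCC6)c(OC)cc45)c(F)c3)c2)c(OC)c1`, is not yet measured. It carries the change (methoxy in place of hydrogen on an aromatic carbon), the same kind of change as that from compound 1 to compound 2 but not the same: the earlier methoxy enters para to a large group, the new one enters ortho to a large group and meta to a methoxy group. Within the data shown here, with the single guide a 4.8-fold higher number from compound 1 to compound 2 (0.68 log units; beyond the scatter) and a differing place, the expected step for compound 4 is a 1.7-fold higher number from compound 3 to compound 4 (0.23 log units; within the scatter), a higher number. Compound 4 is estimated at 600 nM, within a range from 250 nM to 1500 nM.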

Compound 4, half-maximal inhibitory concentration: 630 nM
Compound 4: the middle estimate sits 1.1-fold (0.02 log units) below what was measured; low and high end bracket the measured number.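

In this assay, placing a methoxy on the 4-methoxyphenyl group to give the 2,4-dimethoxyphenyl group produces a 1.8-fold higher number from compound 3 to compound 4 (0.26 log units; within the scatter). Set beside the earlier methoxy addition on the other core, the two steps cannot be told apart: the same change on two cores in this assay, a 4.8-fold higher number (0.68 log units; beyond the scatter) from compound 1 to compound 2 and a 1.8-fold higher number (0.26 log units; within the scatter) from compound 3 to compound 4, 2.6-fold (0.42 log units) apart, within the scatter of two such steps. Among these compounds, this agrees with the change carrying over from one core to the other, but it does not establish that it does, since there are only two steps, the methoxy enters at a different place in each, and only the earlier step lies beyond the scatter.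

As far as these compounds go, it remains open whether the 2,4-dimethoxyphenyl group would read alike with the 4-methylpiperazin-1-yl chain in place of the pyrrolidin-1-yl chain. Also open, from the compounds shown here alone, is how a fluorine, a hydroxyl or an amine would compare with methoxy at this place.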